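The compounds below may be only part of what the source reports. "The series", "measured", "known", "first", "only" and "open" are said of these compounds alone.

Measured compounds:
- compound 1 `C=C/C=C\[C@H](C)[C@H](OC(N)=O)[C@@H](C)[C@H](O)[C@@H](C)C/C(C)=C\[C@H](C)[C@@H](O)[C@@H](C)/C=C\CCc1cccc(OC)c1`, which in a functional assay on MCF7 cells (Homo sapiens) for cytotoxicity (a lower number here means a stronger inhibitor, a higher number a weaker inhibitor), gives 330 nM
- compound 2 `C=C/C=C\[C@H](C)[C@H](OC(N)=O)[C@@H](C)[C@H](O)[C@@H](C)C/C(C)=C\[C@H](C)[C@@H](O)[C@@H](C)/C=C\CCc1ccc(C)c(O)c1`, which in this assay gives 770 nM
- compound 3 `C=C/C=C\[C@H](C)[C@H](OC(N)=O)[C@@H](C)[C@H](O)[C@@H](C)C/C(C)=C\[C@H](C)[C@@H](O)[C@@H](C)/C=C\CCc1cc(O)cc(O)c1`, which in this assay gives 160 nM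

Compound 3 holds the lowest number of the three and is therefore the strongest inhibitor shown: its neighbours are compound 1 with a 2.1-fold lower number from compound 1 to compound 3 (0.31 log units; beyond the scatter) and compound 2 with a 4.8-fold lower number from compound 2 to compound 3 (0.68 log units; beyond the scatter).

Compound 4 `C=C/C=C\[C@H](C)[C@H](OC(N)=O)[C@@H](C)[C@H](O)[C@@H](C)C/C(C)=C\[C@H](C)[C@@H](O)[C@@H](C)/C=C\CCc1sccc1C` is not yet measured. Against compound 3 the difference is 3-methylthiophen-2-yl in place of 3,5-dihydroxyphenyl on a saturated chain carbon, two bonds along the chain from a double-bonded chain carbon.

All three measured steps change the same aromatic end group at this place, so all bear on the question. Adding hydroxyl groups to the ring lowered the number, as a 2.1-fold lower number from compound 1 to compound 3 (0.31 log units; beyond the scatter) and a 4.8-fold lower number from compound 2 to compound 3 (0.68 log units; beyond the scatter) show, while a 2.3-fold higher number from compound 1 to compound 2 (0.37 log units; beyond the scatter) shows that such swaps also go the other way. Compound 4 loses both hydroxyl groups and has no hydrogen-bond donor at all, so in this assay the number for compound 4 is expected to rise by about a 4.1-fold higher number from compound 3 to compound 4 (0.61 log units; beyond the scatter).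

Compound 4 is therefore estimated at 650 nM, within the range 250 nM to 1700 nM.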

Compound 4, half-maximal inhibitory concentration: 370 nM
For compound 4 the middle estimate is 1.8-fold (0.24 log units) above the measured one; low and high end bracket the measured number.
By their numbers in this assay, from the lowest: compound 3; then compounds 1 and 4 (each within the scatter of the next); then compound 2.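

For the compounds shown here, neither a six-membered aromatic ring of carbon only nor a hydrogen-bond donor on the end group is needed for a sub-micromolar-range result in this assay: 3-methylthiophen-2-yl, a five-membered aromatic ring with 1 hetero atom and 0 hydrogen-bond donors, still falls inside the span of the earlier compounds, weaker than the 3,5-dihydroxyphenyl compound (a 2.3-fold higher number from compound 3 to compound 4 (0.36 log units; beyond the scatter)) yet stronger than the 3-hydroxy-4-methylphenyl compound (a 2.1-fold lower number from compound 2 to compound 4 (0.32 log units; beyond the scatter)). Against the 3-methoxyphenyl compound the swap makes no difference that can be read (a 1.1-fold higher number from compound 1 to compound 4 (0.05 log units; within the scatter)). Nothing available here explains why this group behaves as it does.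

As far as these compounds go, how much of the result comes from the ring and how much from its methyl stays open, since a thiophen-2-yl without the methyl and an unsubstituted phenyl are absent from these compounds. Also open, from the compounds shown here alone, is how an amine or a carboxylic acid on the ring, or a longer chain before it, would compare.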